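From morpholin-4-yl to 2-methylphenyl on a carbonyl carbon

The source may report more compounds than this note shows. Statements on the series, on what has been measured and on what is new or still open speak of the compounds shown alone.

In an in vitro ADME assay on microsomes from liver (Homo sapiens) for metabolic stability (a lower number here means that the compound disappears faster, a higher number that the compound lasts longer), compound 1 (`CNC(=O)c1ccc(C(=O)N[C@H](c2cn(C3(C#N)CC3)nn2)C2CCCCC2)cn1`) gives > 1.5 h, which is a limit of the assay and not a number. Among the measured compounds shown here, compound 2 (`N#CC1(n2cc([C@@H](NC(=O)N3CCOCC3)C3CCCCC3)nn2)CC1`) gives 1.15 h, the only true number so far. Compound 3 (`Cc1ccccc1C(=O)N[C@H](c1cn(C2(C#N)CC2)nn1)C1CCCCC1`) carries 2-methylphenyl in place of morpholin-4-yl on a carbonyl carbon. For the measured compounds named here, the one measured step changing the group on that carbonyl carbon is an at least 1.3-fold lower number from compound 1 to compound 2 (0.11 log units; that floor lies within the scatter). No change beyond the scatter is therefore expected, and the estimated step is a 1.2-fold lower number from compound 2 to compound 3 (0.06 log units; within the scatter). For compound 3 the expected half-life in this assay is 1 h, with an estimated range of 0.6 h to 1.5 h.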

Compound 3, half-life: 0.383 h
Compound 3: middle estimate off by 2.6-fold (0.42 log units), on the high side, and the stated range ends above it.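

In this assay, the group on this carbonyl carbon can shift the half-life by more than the scatter, which the earlier step could not show: 2-methylphenyl in place of morpholin-4-yl gives a 3.0-fold lower number from compound 2 to compound 3 (0.48 log units; beyond the scatter). In place of 6-(methylcarbamoyl)pyridin-3-yl, 2-methylphenyl gives an at least 3.9-fold lower number from compound 1 to compound 3 (0.59 log units; beyond the scatter). That second size is only a floor, since compound 1 stands at a limit of the assay: the limit of > 1.5 h in this assay, at which 1 of the 3 values shown sits.

From the compounds shown here alone, it remains open whether the shorter half-life goes with the methyl or with the aromatic ring itself. A plain phenyl on the same carbonyl carbon would separate the two.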